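The source may report more compounds than this note shows. Statements on the series, on what has been measured and on what is new or still open speak of the compounds shown alone.

In an in vitro ADME assay on microsomes from liver (Mus musculus) for pharmacokinetics, read by LC-MS (on this read-out lower numbers stand for slow clearance and higher numbers for fast clearance), compound 2 `Cc1ccc2nc(C)n(-c3ccc(C(=O)NC4CC4)s3)c2c1` reads > 72 mL/min/kg, which is a limit and not a number. Compound 1 `Cc1ccc2c(c1)nc(C)n2-c1ccc(C(=O)NC2CC2)s1` reads > 72 mL/min/kg, which is also a limit. Compound 3 `Cc1nc2cc(OC(F)(F)F)ccc2n1-c1ccc(C(=O)NC2CC2)s1` gives a number, 43 mL/min/kg. The change leading to compound 4 `Cc1nc2ccc(C(F)(F)F)cc2n1-c1ccc(C(=O)NC2CC2)s1` is trifluoromethyl in place of methyl on an aromatic carbon, with trifluoromethyl in place of methyl on an aromatic carbon. For the measured compounds named here, the one measured step that bears on this is an at least 1.6-fold lower number from compound 1 to compound 3 (0.22 log units; that floor lies within the scatter), with trifluoromethoxy in place of methyl on an aromatic carbon. From the compounds shown here alone, that step starts from a limit, so its full size is unknown. A step of similar size toward a lower number is therefore expected, and the expected step is an at least 1.4-fold lower number from compound 2 to compound 4 (0.15 log units; that floor lies within the scatter). For compound 4 the estimated clearance is 50 mL/min/kg, within an expected range of 28 mL/min/kg to 72 mL/min/kg.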

Compound 4, clearance: 68 mL/min/kg
Compound 4: the middle estimate sits 1.4-fold (0.13 log units) below what was measured; the measured number falls inside the stated range.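

In this assay, trifluoromethyl on this aromatic carbon gives compound 4 a measured number, whereas methyl in the same place leaves compound 2 with only a limit. The change brings an at least 1.0-fold lower number from compound 2 to compound 4 (0.02 log units; that floor lies within the scatter). Its full size stays unknown because the step starts from a limit: the limit of > 72 mL/min/kg in this assay, at which 2 of the 4 values shown sit.

The compounds shown leave open how trifluoromethoxy would read on this same carbon. They also leave open what an amine, a nitrile or a longer chain would give there in this assay.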